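The source may report more compounds than this note shows. Statements on the series, on what has been measured and on what is new or still open speak of the compounds shown alone.

Working notes on the series.

Compound 1 `COC(=O)[C@@H](O)[C@H]1C(=O)N2C(C(=O)O)=C(C(C)(C)C)O[C@H]12` is the shortest-lived of the three measured compounds in an ADME assay, in phosphate buffer, at 28 degrees C, at pH 7.0 (on this read-out higher numbers stand for a longer-lived compound and lower numbers for a shorter-lived compound), where compound 1 gives 6.2 h. Compound 2 `CC(C)(C)C1=C(C(=O)O)N2C(=O)[C@H]([C@H](O)c3ccccc3)[C@H]2O1` gives 7 h in this assay, and compound 3 `CC(C)(C)C1=C(C(=O)O)N2C(=O)[C@H]([C@H](O)CCc3ccccc3)[C@H]2O1` gives 21 h. The step of a 1.1-fold higher number from compound 1 to compound 2 (0.05 log units; within the scatter) stays within the scatter, whereas a 3.4-fold higher number from compound 1 to compound 3 (0.53 log units; beyond the scatter) and a 3.0-fold higher number from compound 2 to compound 3 (0.48 log units; beyond the scatter) are modest gains that go beyond it.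

Compound 4 `C[C@@H](F)[C@H]1C(=O)N2C(C(=O)O)=C(C(C)(C)C)O[C@H]12` differs from compound 1 by 1-fluoroethyl in place of hydroxy(methoxycarbonyl)methyl on a saturated ring carbon. Among the measured compounds shown here, none of the measured steps covers this change: they exchange the methoxycarbonyl at the hydroxy-bearing chain carbon for phenyl or phenethyl, and the hydroxy is kept in every measured compound. In compound 4 the hydroxy and the methoxycarbonyl both leave and 1-fluoroethyl enters, so the measured steps give only a loose guide. For the measured compounds named here, the one measured exchange at that position that removes the methoxycarbonyl without adding a longer chain, a 1.1-fold higher number from compound 1 to compound 2 (0.05 log units; within the scatter), lies within the scatter, so no step beyond the scatter is expected here in this assay.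

For compound 4 the expected value in this assay is 8 h, within a range of 4 h to 16 h, which is an estimated step of a 1.3-fold higher number from compound 1 to compound 4 (0.11 log units; within the scatter) and sits inside the scatter.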

Compound 4, half-life: 3.5 h
Estimate against measurement, compound 4: 2.3-fold (0.36 log units) above; the whole stated range lies above it.
By their numbers in this assay, from the lowest: compounds 4, 1 and 2 (each within the scatter of the next); then compound 3.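

Across the change from hydroxy(methoxycarbonyl)methyl to 1-fluoroethyl on the saturated ring carbon of the four-membered ring, the read-out in this assay shows a 1.8-fold lower number from compound 1 to compound 4 (0.25 log units; within the scatter) and so stays close to compound 1. This position therefore tolerates losing the hydroxy, which every earlier compound kept, together with the methoxycarbonyl, without a step beyond the scatter in this one pair. The only gains beyond the scatter still belong to the phenethyl-bearing chain of compound 3, as in a 3.4-fold higher number from compound 1 to compound 3 (0.53 log units; beyond the scatter), and no explanation for the result at this position is available from any accompanying measurement.

Hydroxy and methoxycarbonyl leave and fluorine enters in a single change, so the contribution of each stays unresolved; a hydroxyethyl or a plain ethyl group at this ring carbon would begin to separate them. On these data alone, it also remains open whether the phenethyl gain survives without the hydroxy, which a longer chain carrying fluorine in its place, with the phenyl kept at its end, would address.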